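Swapping Nitro for Tert-Butyl: Expected Cytotoxicity

This account rests on a few compounds, and the source may have more. Where it says the series, first, only, none or still open, it means among the compounds named here.

Of the compounds shown here, three sharing one core have been tested in an ADME assay on HEK-293T cells (Homo sapiens) for cytotoxicity, with a stated time of 48 h; on this read-out lower numbers stand for higher toxicity in this test and higher numbers for lower toxicity in this test. Compound 1 `CCc1ncnc(NC(C)c2ccc(NC(C)=O)cc2)c1Cl` reaches only the limit of the assay, giving > 10000 nM. Compound 3 `CCc1ncnc(NC(C)c2sc3ccccc3c2C)c1Cl` also stops at that limit, with > 10000 nM. Compound 2 `CCc1ncnc(NC(CC)c2ccc([N+](=O)[O-])cc2)c1Cl` likewise gives a limit rather than a number, > 10000 nM. All three sit in the same place, as the limit of > 10000 nM in this assay, at which 3 of the 3 values shown sit, shows, so none stands apart from the others. Compound 4 `CCc1ncnc(NC(CC)c2ccc(C(C)(C)C)cc2)c1Cl` is not yet measured and differs from compound 2 in one place: tert-butyl in place of nitro on an aromatic carbon. Within the data shown here, no step between measured compounds is available to size this change. The expected step is a step that the limit leaves unreadable from compound 2 to compound 4, none beyond the scatter. Compound 4 is therefore estimated at 15000 nM, between 6000 nM and 40000 nM.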

Compound 4, half-maximal cytotoxic concentration: > 10000 nM
Compound 4 was reported as a limit; the forecaster's own chance of this, stated with the estimate: 75%; the middle value lies beyond the limit too.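

No step can be read from compound 2 to compound 4, since both stop at a limit rather than a number: the limit of > 10000 nM in this assay, at which 4 of the 4 values shown sit. On these data alone, whether tert-butyl in place of nitro on an aromatic carbon changes the read-out of this assay at all stays open, as does where any of the four compounds would truly fall.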